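From trifluoromethyl to 4-methylphenyl on a sulfonyl sulfur

A few compounds are considered here, and "the series" means these few. Any claim that something is new, unique, unknown or untested is made for them only; others in the source may bear on it.

In a functional assay on Raji cells (Homo sapiens) for cytotoxicity, with a stated time of 72 h (on this read-out higher numbers stand for an effect only at larger amounts of compound and lower numbers for an effect already at smaller amounts), compound 2 (`C=C[C@@](C)(/C=C/c1ccc(OS(=O)(=O)C(F)(F)F)cc1)CCC=C(C)C`) gives > 26000 nM, which is a limit of the assay and not a number. Compound 1 (`C=C[C@@](C)(/C=C/c1ccc(OCc2ccccc2)cc1)CCC=C(C)C`) gives > 26000 nM, which is likewise a limit. The two compounds therefore share one position, (the limit of > 26000 nM in this assay, at which 2 of the 2 values shown sit), and neither has a measured number.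

Compound 3 (`C=C[C@@](C)(/C=C/c1ccc(OS(=O)(=O)c2ccc(C)cc2)cc1)CCC=C(C)C`) carries 4-methylphenyl in place of trifluoromethyl on a sulfonyl sulfur, with the shared core unchanged: 4-methylphenyl in place of trifluoromethyl on a sulfonyl sulfur.

Going by the values given here, only one measured step bears on this change: a step that the two limits leave unreadable from compound 1 to compound 2, where (trifluoromethyl)sulfonyl takes the place of benzyl on an oxygen on an aromatic ring. It gives no size to carry forward. The expectation therefore rests on (the limit of > 26000 nM in this assay, at which 2 of the 2 values shown sit), and no step beyond the usual scatter is expected in this assay. Compound 3 is expected to remain at or near the same limit, although two compounds offer only thin support for this. The estimated step is a number no higher from compound 2 to compound 3 (the limit leaves the size open). For compound 3 the estimated value is 26000 nM, with an expected range from 12000 nM to 40000 nM.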

Compound 3, half-maximal effective concentration: > 26000 nM
Compound 3: no number, only a limit; the forecaster's own chance of this, stated with the estimate: 80%; the middle value sits exactly at the limit.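

In this assay compound 3 gives > 26000 nM, which is a limit and not a number. The step from compound 2 to compound 3 therefore cannot be read, and the compounds shown share one position: the limit of > 26000 nM in this assay, at which 3 of the 3 values shown sit. They leave open whether any compound with this shared core reaches a measured number in this assay.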